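The source may report more compounds than this note shows. Statements on the series, on what has been measured and on what is new or still open speak of the compounds shown alone.

Compound 1 `c1ccc(CNC(c2ccc[nH]2)c2nnc(-c3ccccc3)o2)cc1` gives 216000 nM in a functional assay on MCF7 cells (Homo sapiens) for cytotoxicity, read by MTT assay, with a stated time of 24 h (a higher number here means a weaker inhibitor, a lower number a stronger inhibitor), the highest number among the three measured compounds. Compound 2 `Clc1ccc(-c2nnc(C(NCc3ccccc3)c3ccc[nH]3)o2)cc1Cl` gives 13900 nM in this assay, and compound 3 `Brc1ccc(-c2nnc(C(NCc3ccccc3)c3ccc[nH]3)o2)cc1` gives 96600 nM. The move from compound 1 to compound 4 `COc1ccc(CNC(c2ccc[nH]2)c2nnc(-c3ccccc3)o2)cc1` is methoxy in place of hydrogen on an aromatic carbon; read one bond further out, it turns benzyl into 4-methoxybenzyl. The measured steps lie elsewhere, on the phenyl that sits on the shared core: a 16-fold lower number from compound 1 to compound 2 (1.19 log units; beyond the scatter) and a 2.2-fold lower number from compound 1 to compound 3 (0.35 log units; beyond the scatter), while a 6.9-fold higher number from compound 2 to compound 3 (0.84 log units; beyond the scatter). None of them touches the benzyl, so they bear on the present step only in showing that substituents on an aromatic ring can shift the numbers, sometimes by a large margin. For the measured compounds named here, with no direct precedent, compound 4 is expected to give a number close to that of compound 1, perhaps a little lower, amounting to a 1.4-fold lower number from compound 1 to compound 4 (0.16 log units; within the scatter). For compound 4 the estimate is 150000 nM, within a range from 50000 nM to 450000 nM.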

Compound 4, half-maximal inhibitory concentration: 142000 nM
The estimate for compound 4 lay 1.1-fold (0.02 log units) above the measured number, and the stated range covers the measured number.
By their numbers in this assay, from the lowest: compound 2; then compounds 3, 4 and 1 (each within the scatter of the next, the first and the last beyond it).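

Among the compounds shown, only compound 4 carries a substituent on the benzyl, and in this assay the change from benzyl to 4-methoxybenzyl amounts to a 1.5-fold lower number from compound 1 to compound 4 (0.18 log units; within the scatter) and so stays within the usual scatter. Methoxy at this place, para to a large group, therefore has no measurable effect on the number, unlike the change to 3,4-dichlorophenyl on the phenyl on the shared core, which gives a 16-fold lower number from compound 1 to compound 2 (1.19 log units; beyond the scatter) and lies beyond it. Nothing available here explains the small size of the step.

Going by these compounds, whether bromo on the benzyl would shift the number as it does on the phenyl on the shared core remains open. So does the outcome with an amine or a carboxylic acid at this place, or with methoxy on that other phenyl.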